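This account rests on a few compounds, and the source may have more. Where it says the series, first, only, none or still open, it means among the compounds named here.

Of the compounds shown here, three share one core and have been measured in an ADME assay on HEK-293T cells (Homo sapiens) for cytotoxicity, read by MTT assay, with a stated time of 24 h; on this read-out lower numbers stand for higher toxicity in this test and higher numbers for lower toxicity in this test. Compound 1 `O=C(c1ccncc1)n1c(-c2cn(-c3ccccc3)nc2-c2ccc(F)cc2)nc2ccccc21` gives 151000 nM. Compound 2 `Cc1ccc(C(=O)n2c(-c3cn(-c4ccccc4)nc3-c3ccc(F)cc3)nc3ccccc32)cn1` gives 137000 nM. Compound 3 `Cc1ccc(-c2nn(-c3ccccc3)cc2-c2nc3ccccc3n2C(=O)c2ccc(Cl)cc2)cc1` gives 216000 nM; this is the highest of the three numbers, but its gaps to compound 1 and to compound 2 are both within the scatter, so no order among them can be read from these values. Among the measured compounds shown here, the only measured step that alters one place, a 1.1-fold lower number from compound 1 to compound 2 (0.04 log units; within the scatter), lies within the scatter and concerns the group on the carbonyl carbon.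

Compound 4 `O=C(c1ccc(Cl)cc1)n1c(-c2cn(-c3ccccc3)nc2-c2ccc(F)cc2)nc2ccccc21` differs from compound 3 at one place: fluoro in place of methyl on an aromatic carbon. For the measured compounds named here, no measured step touches this position, and the one step that does exist changes a different part of the molecule, so it offers no reason to expect a shift. The step from compound 3 to compound 4 in this assay is therefore estimated to be small, a 1.1-fold lower number from compound 3 to compound 4 (0.03 log units; within the scatter), with no clear direction. Compound 4 is expected to give about 200000 nM, between 100000 nM and 400000 nM.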

Compound 4, half-maximal cytotoxic concentration: 179000 nM
Estimate against measurement, compound 4: 1.1-fold (0.05 log units) above; low and high end bracket the measured number.
By their numbers in this assay, from the lowest: compounds 2, 1, 4 and 3 (each within the scatter of the next).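

In this assay, among the compounds shown here, fluoro in place of methyl on an aromatic carbon, para to a large group, gives a 1.2-fold lower number from compound 3 to compound 4 (0.08 log units; within the scatter) and so puts a first measured step at this position, one that stays within the scatter. On the carbonyl carbon, 4-chlorophenyl in place of 6-methylpyridin-3-yl gives a 1.3-fold higher number from compound 2 to compound 4 (0.12 log units; within the scatter) and 4-chlorophenyl in place of pyridin-4-yl gives a 1.2-fold higher number from compound 1 to compound 4 (0.07 log units; within the scatter), so a ring of carbon only and these two nitrogen-containing rings cannot be told apart in this test. Nothing at hand bears on why these numbers take the values they do.

For the compounds shown here, the methyl-to-fluoro change is seen only with 4-chlorophenyl on the carbonyl carbon, so its size with other groups there stays open. Going by these compounds, whether an amine, a carboxylic acid or a longer chain in that aromatic place would move the number beyond the scatter also remains unknown.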